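A few compounds are considered here, and "the series" means these few. Any claim that something is new, unique, unknown or untested is made for them only; others in the source may bear on it.

Compound 1 `C/C(=C\CC/C(C)=C/CC[C@@H]1[C@@]2(C)CCC(=O)C(C)(C)[C@H]2CC[C@@]1(C)O)CC/C=C(\C)C(=O)OCc1cn(-c2ccc([N+](=O)[O-])cc2)nn1`: in a functional assay on DU-145 cells (Homo sapiens) for antiproliferative activity, read by MTT assay, with a stated time of 48 h (a higher number here means a weaker inhibitor, a lower number a stronger inhibitor), compound 1 gives > 150000 nM, which is a limit of the assay rather than a number.
Compound 2 `C/C(=C\CC/C(C)=C/CC[C@@H]1[C@@]2(C)CCC(=O)C(C)(C)[C@H]2CC[C@@]1(C)O)CC/C=C(\C)C(=O)OCc1cn(-c2ccccc2[N+](=O)[O-])nn1`: in this assay compound 2 gives > 150000 nM, again a limit of the assay.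

Compound 2 thus stands only at a limit, with no exact number known. The step from compound 1 to compound 2 a step that the two limits leave unreadable from compound 1 to compound 2 swaps a 4-nitrophenyl for a 2-nitrophenyl on an aromatic nitrogen, and since both ends rest at the limit of > 150000 nM in this assay, at which 2 of the 2 values shown sit, its size cannot be read. Compound 3 `C/C(=C\CC/C(C)=C/CC[C@@H]1[C@@]2(C)CCC(=O)C(C)(C)[C@H]2CC[C@@]1(C)O)CC/C=C(\C)C(=O)OCc1cn(-c2ccc(C(C)(C)C)cc2)nn1` is not yet measured. It differs from compound 2 by 4-(tert-butyl)phenyl in place of 2-nitrophenyl on an aromatic nitrogen, with 4-(tert-butyl)phenyl entering in place of 2-nitrophenyl on an aromatic nitrogen of a five-membered aromatic ring with 3 nitrogen. For the measured compounds named here, only that unreadable step bears on this change, so no direction beyond the scatter can be expected, and the step from compound 2 to compound 3 is expected to be a step that the limit leaves unreadable from compound 2 to compound 3. Compound 3 is estimated at 200000 nM, within 60000 nM to 600000 nM, most likely again reported only as a limit.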

Compound 3, half-maximal inhibitory concentration: > 150000 nM
Compound 3 was reported as a limit; the forecaster's own chance of this, stated with the estimate: 70%; the middle value does not contradict the limit.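

In this assay compound 3, like compound 1 and compound 2, gives only a limit of the assay, so no step among these three compounds can be read: the limit of > 150000 nM in this assay, at which 3 of the 3 values shown sit.
The compounds shown leave open whether any group on this aromatic nitrogen would give an exact value, and how far these three compounds truly differ.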